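Dimethylcarbamoyl in place of aminomethyl on the shared core

This account rests on a few compounds, and the source may have more. Where it says the series, first, only, none or still open, it means among the compounds named here.

In a functional assay (aorta) with Rattus norvegicus as the target (a lower number here means that less compound is needed, a higher number that more compound is needed for the effect), compound 1 (`COc1ccc(-c2nc(/N=C(\N)NC(C)C)sc2-c2ccc(OC)cc2)cc1`) gives 9.1 uM and compound 2 (`COc1ccc(-c2nc(CN)sc2-c2ccc(OC)cc2)cc1`) gives 7.7 uM. Compound 2 therefore stands level with compound 1, the two values lying within the scatter of each other.

Compound 3 (`COc1ccc(-c2nc(C(=O)N(C)C)sc2-c2ccc(OC)cc2)cc1`) carries dimethylcarbamoyl in place of aminomethyl on an aromatic carbon, at the same place on the shared core: dimethylcarbamoyl in place of aminomethyl on an aromatic carbon.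

Going by the values given here, only one measured step bears on this change. That step, a 1.2-fold lower number from compound 1 to compound 2 (0.07 log units; within the scatter), exchanged one group at this place for another and stayed within the scatter. Among the compounds with values here, no measured compound carries dimethylcarbamoyl, so this is weak support, and the direction stays open. The expected step, a 1.0-fold higher number from compound 2 to compound 3 (0.02 log units; within the scatter), is estimated to stay within the scatter. For compound 3 the estimated value in this assay is 8 uM, with an expected range of 2.5 uM to 30 uM.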

Compound 3, concentration for half-maximal effect: 3 uM
Compound 3: the middle estimate sits 2.7-fold (0.43 log units) above what was measured; the measured number falls inside the stated range.
By their numbers in this assay, from the lowest: compound 3; then compounds 2 and 1 (each within the scatter of the next).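

Notes on this position: in this assay the aromatic carbon does respond to its substituent, since dimethylcarbamoyl in place of aminomethyl gives a 2.6-fold lower number from compound 2 to compound 3 (0.41 log units; beyond the scatter), whereas the earlier exchange at this place stayed within the scatter. Dimethylcarbamoyl also holds up against the larger group of compound 1, with a 3.0-fold lower number from compound 1 to compound 3 (0.48 log units; beyond the scatter), so the lower number stands against both earlier groups. No measurement on hand accounts for this step.

The compounds shown leave open whether the step follows the carbonyl or the two methyl groups on the amide nitrogen. A primary carboxamide, a carboxylic acid or a diethylcarbamoyl group at this place would separate these readings and show how far the lower number extends.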